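The source may report more compounds than this note shows. Statements on the series, on what has been measured and on what is new or still open speak of the compounds shown alone.

Measured so far:
- compound 1 `COc1ccc(Oc2ccccc2-c2ccsc2S(=O)(=O)N2CCN(C(=S)Nc3ccc([N+](=O)[O-])cc3)CC2)cc1OC` gives > 50000 nM as a limit
- compound 2 `COc1ccc(NC(=O)NCCNS(=O)(=O)c2sccc2-c2ccc(C)cc2Oc2ccc(O)c(O)c2)cc1` gives 6100 nM as a number
- compound 3 `Cc1ccc(-c2ccsc2S(=O)(=O)NCCNC(=S)Nc2ccc([N+](=O)[O-])cc2)c(Oc2ccc(O)c(O)c2)c1` gives 2900 nM as a number

In a functional assay on HL-60 cells (Homo sapiens) for inhibition, read by CCK-8 assay, with a stated time of 48 h (a higher number here means a weaker inhibitor, a lower number a stronger inhibitor), all three were read. Compound 1 stands only at the limit of > 50000 nM in this assay, at which 1 of the 3 values shown sits, and so has a limit, not a number. The change to compound 4 `COc1ccc(Oc2ccccc2-c2ccsc2S(=O)(=O)N2CCN(C(=O)Nc3ccc([N+](=O)[O-])cc3)CC2)cc1OC` is a group of 12 heavy atoms (7 carbon, 2 nitrogen, 3 oxygen; one six-membered aromatic ring of carbon only) in place of a group of 12 heavy atoms (7 carbon, 2 nitrogen, 2 oxygen, 1 sulfur; one six-membered aromatic ring of carbon only), on an amine nitrogen in a ring and nothing else. For the measured compounds named here, the one measured step that bears on it is a 2.1-fold lower number from compound 2 to compound 3 (0.32 log units; beyond the scatter) and it is modest. Going by the values given here, it ends on a group of the same count as the one leaving compound 1, but it starts from a group other than the one entering here, so it guides this change only loosely. No step beyond the scatter is expected, the expected one being a number no higher from compound 1 to compound 4 (the limit leaves the size open) on these numbers. Compound 4 is estimated at 50000 nM with a range from 15000 nM to 100000 nM and may well return only a limit.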

Compound 4, half-maximal inhibitory concentration: > 50000 nM
Compound 4 ended at the assay's limit; the forecaster's own chance of this, stated with the estimate: 65%; the middle value sits exactly at the limit.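

Compound 1 and compound 4 both stand at a limit and not at a number, so the step between them cannot be read: the limit of > 50000 nM in this assay, at which 2 of the 4 values shown sit. The compounds shown leave open how the (4-nitrophenyl)carbamoyl group compares with the group it replaces.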